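The source may hold more compounds than are shown below. What is called first, only, known or untested is meant among the compounds shown, and "the series" means these compounds.

In a functional assay on the whole organism with Rattus norvegicus as the target (a higher number here means that more compound is needed for the effect, a lower number that less compound is needed), compound 1 `N=c1sc2cc(OC(F)(F)F)ccc2n1Cc1ccccc1` gives > 10 mg/kg, which is a limit of the assay and not a number. Among the compounds with values here, compound 2 `CS(=O)(=O)CCn1c(=N)sc2cc(OC(F)(F)F)ccc21` gives 1.8 mg/kg, the only actual number so far. Within the data shown here, the one measured step, an at least 5.5-fold lower number from compound 1 to compound 2 (0.74 log units; beyond the scatter), is a bound rather than an exact size, as it rests on (the limit of > 10 mg/kg in this assay, at which 1 of the 2 values shown sits). It shows only that this side chain can move the dose beyond the scatter.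

Compound 3 `C[S+]([O-])CCCn1c(=N)sc2cc(OC(F)(F)F)ccc21` replaces methylsulfonyl on a saturated chain carbon, two bonds along the chain from an aromatic nitrogen: a group of 4 heavy atoms (2 carbon, 1 oxygen, 1 sulfur; no ring) in place of a group of 4 heavy atoms (1 carbon, 2 oxygen, 1 sulfur; no ring), on a saturated chain carbon, two bonds along the chain from an aromatic nitrogen. Among the measured compounds shown here, both groups contain one sulfur and no ring, and no measured step covers this exchange directly. The expected change is a 1.4-fold higher number from compound 2 to compound 3 (0.14 log units; within the scatter), which means no shift beyond the scatter is expected in this assay. For compound 3 the estimated dose is 2.5 mg/kg, with an expected range of 0.8 mg/kg to 8 mg/kg.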

Compound 3, dose for half-maximal effect: 2.3 mg/kg
The estimate for compound 3 lay 1.1-fold (0.04 log units) above the measured number; the measured number falls inside the stated range.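

In this assay the exchange on a saturated chain carbon, two bonds along the chain from an aromatic nitrogen, gives a 1.3-fold higher number from compound 2 to compound 3 (0.11 log units; within the scatter), so methylsulfonyl and the group that enters cannot be told apart at this place. A second sulfur-bearing side chain therefore also stands clear of the phenyl side chain, with an at least 4.3-fold lower number from compound 1 to compound 3 (0.63 log units; beyond the scatter). This size is again a bound and not an exact figure: the limit of > 10 mg/kg in this assay, at which 1 of the 3 values shown sits.

As far as these compounds go, whether sulfur is needed at all remains open, and a side chain ending in an amine or a carboxylic acid would test that. Also open, from the compounds shown here alone, is how much of the dose depends on the end group and how much on chain length, which methylsulfonyl on a longer chain would help to separate.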